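This account rests on a few compounds, and the source may have more. Where it says the series, first, only, none or still open, it means among the compounds named here.

In a functional assay on HeLa cells (Homo sapiens) for inhibition, read by MTT assay, with a stated time of 72 h (a higher number here means a weaker inhibitor, a lower number a stronger inhibitor), compound 1 (`COc1cc(NC(=O)/C=C/c2cccc(OCc3ccccc3)c2)cc(OC)c1OC`) gives 2200 nM and compound 2 (`C=C(Br)C(=O)Nc1cccc(/C=C/C(=O)Nc2ccc(Cl)cc2)c1`) gives 2800 nM. Among the measured compounds shown here, these two numbers lie within the usual scatter of each other, so compound 1 stands level with the only other measured compound. Compound 3 (`C=C(Br)C(=O)Nc1cccc(/C=C/C(=O)Nc2cc(OC)c(OC)c(OC)c2)c1`) has not yet been measured. It keeps the rest of compound 1 but exchanges one group on an aromatic carbon, meta to a large group: ((1-bromoethenyl)carbonyl)amino in place of benzyloxy on an aromatic carbon. The entering ((1-bromoethenyl)carbonyl)amino group also occurs in compound 2, which gives 2800 nM. For the measured compounds named here, compounds 1 and 2 differ in more than one place, however, so no measured step isolates this exchange. Compound 3 unites the retained part of compound 1 with the entering group of compound 2, and a moderate move toward a lower number in this assay is therefore expected, though with wide uncertainty. The expected change is a 3.1-fold lower number from compound 1 to compound 3 (0.50 log units; beyond the scatter). For compound 3 the estimated value is 700 nM, with an expected range from 120 nM to 3000 nM.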

Compound 3, half-maximal inhibitory concentration: 880 nM
Beside the measured number, compound 3's estimate is 1.3-fold (0.10 log units) below it; low and high end bracket the measured number.
By their numbers in this assay, from the lowest: compound 3; then compounds 1 and 2 (each within the scatter of the next).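

In this assay, among the compounds shown here, exchanging benzyloxy for the ((1-bromoethenyl)carbonyl)amino group, at a place on an aromatic carbon, meta to a large group, gives a 2.5-fold lower number from compound 1 to compound 3 (0.40 log units; beyond the scatter) as a modest step, and this is the first single exchange that can be read at this position. The six-membered aromatic ring of the benzyloxy group is therefore not required for a number of this order while the rest of compound 1 is kept, since compound 3 has no ring in the entering group and carries a hydrogen-bond donor that benzyloxy lacks. No measurement shown here gives a reason for this step.

The single exchange alters the ring, the bromine, the double bonds and the amide hydrogen together, so the compounds shown cannot assign the step to any one of these features. On these data alone, it remains open how the same aromatic carbon would respond to a propanoylamino group, an acryloylamino group without bromine, or a plain amino group, and whether the same exchange would give a step of similar size on the core of another compound.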